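Aryl Sulfonyl Replacing Succinyl: Cytotoxicity Expected to Rise

This account rests on a few compounds, and the source may have more. Where it says the series, first, only, none or still open, it means among the compounds named here.

Measured compounds:
compound 1, `C=CCNC(=S)NC1=C(C#N)C(c2ccc(Cl)cc2Cl)C2=C(CCCC2=O)N1c1ccc(S(N)(=O)=O)cc1`, 40%
compound 2, `N#CC1=C(NC(=S)Nc2ccccc2)N(c2ccc(S(N)(=O)=O)cc2)C2=C(C(=O)CCC2)C1c1ccc(Cl)cc1Cl`, 95%
compound 3, `N#CC1=C(NC(=O)CCC(=O)O)N(c2ccc(S(N)(=O)=O)cc2)C2=C(C(=O)CCC2)C1c1ccc(Cl)cc1Cl`, 60%

In a functional assay on Ehrlich cells (Mus musculus) for cytotoxicity, read by trypan blue exclusion, with a stated time of 2 h, tested at 100 ug/mL (a lower number here means a weaker effect, a higher number a stronger effect of the compound at the concentration tested), compound 3 stands second highest of the three, with compound 1 below it and compound 2 above it. Compound 4, `N#CC1=C(NS(=O)(=O)c2ccc(Br)cc2)N(c2ccc(S(N)(=O)=O)cc2)C2=C(C(=O)CCC2)C1c1ccc(Cl)cc1Cl`, differs from compound 3 in one place: (4-bromophenyl)sulfonyl in place of (2-carboxyethyl)carbonyl on an amine nitrogen. Within the data shown here, two measured steps bear on this. The step of a number 35 percentage points lower from compound 2 to compound 3 (beyond the scatter) shows that exchanging a group carrying an aromatic ring for the carboxyethylcarbonyl group lowered the read-out strongly, while a number 20 percentage points higher from compound 1 to compound 3 (beyond the scatter) was modest. Since compound 4 again carries an aromatic ring on that nitrogen, a rise beyond the scatter is expected, though the sulfonyl link is new and untested here. The expected step is a number 18 percentage points higher from compound 3 to compound 4 (beyond the scatter). Compound 4 is therefore estimated at 78%, within a range from 55% to 98%.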

Compound 4, a percentage reported as activity, at one concentration (the size of the read-out at that concentration, not a potency): 100%
Compound 4: middle estimate off by 22 percentage points, on the low side; measured number above the stated range.
By their numbers in this assay, from the lowest: compound 1; then compound 3; then compounds 2 and 4 (each within the scatter of the next).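

Putting (4-bromophenyl)sulfonyl in place of (2-carboxyethyl)carbonyl on this amine nitrogen gives a number 40 percentage points higher from compound 3 to compound 4 (beyond the scatter) in this assay, so the sulfonyl link, new at this position, does not stand in the way of a high read-out. The step of a number 5 percentage points higher from compound 2 to compound 4 (within the scatter) means these two different ring-bearing groups cannot be told apart here, while a number 60 percentage points higher from compound 1 to compound 4 (beyond the scatter) shows how far the sulfonyl group stands from the allyl-bearing group of compound 1. Neither compound settles whether the bromine matters, which a plain phenylsulfonyl group or a methylsulfonyl group on the same nitrogen could test. Nothing given here explains the differences between these groups.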